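Urea to amide: compound 4 alongside its measured relatives

The source may report more compounds than this note shows. Statements on the series, on what has been measured and on what is new or still open speak of the compounds shown alone.

Compound 1 `COc1cc(Cl)cc(-c2nn(-c3cccc(NC(=O)Nc4ccc(Cl)c(C(F)(F)F)c4)c3)cc2-c2ccncc2)c1` was tested in a functional assay on MDA-MB-231 cells (Homo sapiens) for inhibition, read by sulforhodamine B assay, with a stated time of 48 h, tested at 10 uM (a lower number here means a stronger effect, a higher number a weaker effect of the compound at the concentration tested), where compound 1 gives -30.8%. Among the three measured compounds it holds the second highest number. Its nearest neighbour is compound 3 `COc1cc(Cl)cc(-c2nn(-c3cccc(NC(=O)Nc4ccc(Cl)c(Cl)c4)c3)cc2-c2ccncc2)c1`, which in this assay gives -21%; the step from compound 1 to compound 3 is a number 9.8 percentage points higher from compound 1 to compound 3 (within the scatter), a change of chloro in place of trifluoromethyl on an aromatic carbon. The furthest is compound 2 `COc1cc(Cl)cc(-c2nn(-c3cccc(NC(=O)Nc4cc(C(F)(F)F)cc(C(F)(F)F)c4)c3)cc2-c2ccncc2)c1`, which in this assay gives -75%, a number well below compound 1 and beyond the scatter.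

Compound 4 `COc1cc(Cl)cc(-c2nn(-c3cccc(NC(=O)c4cccc(C(F)(F)F)c4)c3)cc2-c2ccncc2)c1` has not yet been measured. It differs from compound 1 by 3-(trifluoromethyl)phenyl in place of (4-chloro-3-(trifluoromethyl)phenyl)amino on a carbonyl carbon. Among the measured compounds shown here, none of the measured steps touches this kind of change: the only recorded step swaps one aromatic substituent for another and stays within the scatter, whereas here a hydrogen-bond donor and a chlorine are removed together. For the measured compounds named here, with no step of the same kind to lean on, the expected step from compound 1 to compound 4 is a number 15.8 percentage points higher from compound 1 to compound 4 (beyond the scatter), leaning toward a weaker effect. Compound 4 is therefore estimated to give -15% in this assay, within a range from -45% to 15%.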

Compound 4, a percentage reported as activity, at one concentration (the size of the read-out at that concentration, not a potency): 21.4%
Beside the measured number, compound 4's estimate is 36.4 percentage points below it; the measured number lies above the stated range.
By their numbers in this assay, from the lowest: compound 2; then compounds 1 and 3 (each within the scatter of the next); then compound 4.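

At this carbonyl carbon, replacing the substituted phenylamino group with 3-(trifluoromethyl)phenyl produces a large move toward a weaker effect in this assay: a number 52.2 percentage points higher from compound 1 to compound 4 (beyond the scatter), and a number 42.4 percentage points higher from compound 3 to compound 4 (beyond the scatter). The earlier step changed only an aromatic substituent and stayed within the scatter, whereas this change, read from either urea, goes beyond it, so the link on the carbonyl carbon matters far more here than that substituent swap did. Nothing available explains why the number moves this way.

Since compound 4 loses the amino nitrogen with its hydrogen-bond donor and also differs from each urea in its aromatic substituents, the shown compounds cannot say which of these changes carries the step. They also leave open how a methylene or methylamino group would read on that carbonyl carbon.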